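Removing a hydroxypropyl group from a ring nitrogen

The source may report more compounds than this note shows. Statements on the series, on what has been measured and on what is new or still open speak of the compounds shown alone.

Measured compounds:
compound 1 `Cn1nc(Cc2nnc(SCCCCCCCC(=O)Nc3ccc(Cl)cc3Cl)[nH]2)c2ccccc2c1=O` — 2400 nM
compound 2 `Cn1c(Cc2nn(CCCO)c(=O)c3ccccc23)nnc1SCCCCCCCC(=O)Nc1ccc(Cl)cc1Cl` — 3900 nM

Of the compounds shown here, two have been measured in an assay on isolated protein for binding affinity to interleukin-15 (Homo sapiens), read by surface plasmon resonance; a higher number here means weaker binding, a lower number tighter binding. Compound 1 gives 2400 nM in this assay, and compound 2 gives 3900 nM. Compound 2 has the highest of the two numbers, but the gap to compound 1 is within the scatter of repeated measurements, so the two cannot be ordered. Within the data shown here, no step between compounds that differ in a single place is available, so there is no measured guide for how a change of this kind moves the number.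

Compound 3 `Cn1c(Cc2n[nH]c(=O)c3ccccc23)nnc1SCCCCCCCC(=O)Nc1ccc(Cl)cc1Cl` has not yet been measured. It differs from compound 2 by one change: hydrogen in place of 3-hydroxypropyl on an aromatic nitrogen. Without a comparable measured step, nothing in the data points to a shift in either direction, and no step beyond the scatter is expected in this assay. For compound 3 the estimated value in this assay is 3300 nM, with a range from 1200 nM to 9000 nM, so the expected step is a 1.2-fold lower number from compound 2 to compound 3 (0.07 log units; within the scatter).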

Compound 3, dissociation constant: "not active" (no number reported)
The entry for compound 3 holds no number, and the estimate cannot be compared.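

In this assay, among these compounds, compound 3 is reported as "not active", without a number, so no step from compound 2 to compound 3 can be read. Nothing shown here bears on this result. The compounds shown leave open how far binding changes when hydrogen takes the place of 3-hydroxypropyl on the aromatic nitrogen.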